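This account rests on a few compounds, and the source may have more. Where it says the series, first, only, none or still open, it means among the compounds named here.

Notes on the series. Compound 1 `O=C1/C(=C/c2ccccc2F)CN(S(=O)(=O)c2ccc(O[N+](=O)[O-])cc2)C/C1=C\c1ccccc1F` gives 6200 nM in a functional assay on SMMC-7721 cells (Homo sapiens) for cytotoxicity, read by MTT assay, with a stated time of 24 h; on this read-out higher numbers stand for weaker inhibition and lower numbers for stronger inhibition. Compound 2 `O=C1/C(=C/c2ccccc2F)CN(S(=O)(=O)c2ccc(C(F)(F)F)cc2)C/C1=C\c1ccccc1F` differs from it at one point trifluoromethyl in place of nitrooxy on an aromatic carbon and in this assay compound 2 gives 5200 nM; the step is a 1.2-fold lower number from compound 1 to compound 2 (0.08 log units; within the scatter). Compound 3 `O=C1/C(=C/c2cccc(F)c2)CN(S(=O)(=O)c2ccc(O[N+](=O)[O-])cc2)C/C1=C\c1cccc(F)c1` has the same atoms as compound 1 joined differently; the difference between the two cores is not broken down here. In this assay compound 3 gives 15300 nM, the highest of the three numbers, with compound 1 nearest and compound 2 furthest, both beyond the scatter. Compound 4 `O=C1/C(=C/c2cccc(F)c2)CN(S(=O)(=O)c2ccc(C(F)(F)F)cc2)C/C1=C\c1cccc(F)c1` is not yet measured; it stands to compound 3 as compound 2 stands to compound 1 (trifluoromethyl in place of nitrooxy on an aromatic carbon), the same change at the same place. Because the matched step was a 1.2-fold lower number from compound 1 to compound 2 (0.08 log units; within the scatter), the step is expected to be small, a 1.2-fold lower number from compound 3 to compound 4 (0.07 log units; within the scatter). Compound 4 is estimated at 13000 nM, expected to fall between 7000 nM and 25000 nM.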

Compound 4, half-maximal inhibitory concentration: 4200 nM
Estimate against measurement, compound 4: 3.1-fold (0.49 log units) above, outside the stated range (below it).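

On the core of compound 3, trifluoromethyl in place of nitrooxy gives a 3.6-fold lower number from compound 3 to compound 4 (0.56 log units; beyond the scatter) in this assay. The size of this step does not carry from one core to the other: the same change on two cores in this assay, a 1.2-fold lower number (0.08 log units; within the scatter) from compound 1 to compound 2 and a 3.6-fold lower number (0.56 log units; beyond the scatter) from compound 3 to compound 4, 3.1-fold (0.49 log units) apart, beyond the scatter of two such steps

This rests on a single matched pair per core, so it shows that the step cannot be transferred unchanged between these two cores, but it does not show what in the cores sets the difference or how the step would run on a further core.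

On these data alone, whether an amine or a carboxylic acid in place of nitrooxy would also give steps that differ between the two cores remains open. Also open, as far as these compounds go, is how the same change would run on a core carrying chlorine in place of fluorine.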